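Chloro to hydroxy on the side-chain ring

This account rests on a few compounds, and the source may have more. Where it says the series, first, only, none or still open, it means among the compounds named here.

Compound 1 `COc1cc2oc(=O)cc(COC(=O)/C=C/c3cc(OC)c(OC)c(OC)c3)c2cc1OC` and compound 2 `COc1cc2oc(=O)cc(COC(=O)/C=C/c3ccc(Cl)cc3)c2cc1OC` share the same core and differ only in the groups carried on the aromatic ring at the far end of the side chain. In a functional assay on HCT-116 cells (Homo sapiens) for inhibition, tested at 3 ug/mL (on this read-out lower numbers stand for less inhibition and higher numbers for more inhibition at the one concentration tested (going by the name of the read-out)), compound 1 gives 18.7%. For compound 2 this assay reports only a limit, < 10%, so no number is known for it. Compound 2 thus stands at the limit of < 10% in this assay, at which 1 of the 2 values shown sits.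

Compound 3 `COc1cc2oc(=O)cc(COC(=O)/C=C/c3ccc(O)cc3)c2cc1OC` has not yet been measured. It arises from compound 2 by a single change: hydroxy in place of chloro on an aromatic carbon. Among the compounds with values here, no step between two measured compounds is available here, so nothing measured shows how this exchange acts on the read-out. The expectation is therefore a small step at most, with no change beyond the usual scatter. Compound 3 is expected to give about 12%, within a range from 4% to 24%, and there is a fair chance that this assay again reports only the limit. This estimate means a step of a number at least 2 percentage points higher from compound 2 to compound 3 (that floor lies within the scatter) that is expected to stay inside the scatter of repeated measurements.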

Compound 3, a percentage reported as inhibition, at one concentration (the size of the read-out at that concentration, not a potency): 19.7%
Compound 3: the middle estimate sits 7.7 percentage points below what was measured; measured number inside the range.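

On the aromatic carbon para to a large group, hydroxy in place of chloro in this assay gives a number at least 9.7 percentage points higher from compound 2 to compound 3 (that floor lies within the scatter). Within the data shown here, this is the first direct view of the exchange at this position, and it turns a result reported only as a limit into a measured number for compound 3. The true size of the step cannot be read, however, and its floor does not establish a change beyond the usual scatter, because compound 2 has only a limit: the limit of < 10% in this assay, at which 1 of the 3 values shown sits.

The compounds shown leave open whether an amine, a methoxy group alone or a carboxylic acid on the same aromatic carbon would read like hydroxy or like chloro, and whether the result for hydroxy depends on this exact place on the ring. Since this assay reports the size of the effect at one concentration, it also leaves open how compound 3 would behave at other concentrations, so this single value cannot serve as a measure of potency.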